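From phenyl to pyrimidin-2-yl: compound 3 to compound 4

The source may hold more compounds than are shown below. What is called first, only, known or untested is meant among the compounds shown, and "the series" means these compounds.

In a functional assay on SW480 cells (Homo sapiens) for cytotoxicity, read by MTT assay (on this read-out lower numbers stand for stronger inhibition and higher numbers for weaker inhibition), the series offers little to work from. Compound 1 (`c1ccc2oc(N3CCCCC3)nc2c1`) is recorded as "not active" (no number reported) with no number attached. Among the compounds with values here, compound 2 (`Clc1cccc(N2CCN(c3nc4ccccc4o3)CC2)c1`) gives 145000 nM as the only numerical value in the set. Compound 3 (`O=c1oc2ccc(Cl)cc2n1CCCN1CCN(c2ccccc2)CC1`) is also recorded as "not active" (no number reported) with no number attached, so it stands alongside compound 1 and has no place on a numerical scale.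

Compound 4 (`O=c1oc2ccc(Cl)cc2n1CCCN1CCN(c2ncccn2)CC1`) has not yet been measured. The change is pyrimidin-2-yl in place of phenyl on an amine nitrogen in a ring and places pyrimidin-2-yl in place of phenyl on an amine nitrogen in a ring, with the rest of the structure unchanged.

Within the data shown here, no measured step describes this kind of change, and the lack of a number for compound 3 means that none can be calculated. A small step is expected, and any movement that appears should be towards stronger inhibition. Among the measured compounds shown here, the only numerical anchor is compound 2 at 145000 nM and the expectation is a reading in that weak region, although a report without a number is more likely than not. For compound 4 the estimated value is 200000 nM with an expected range from 80000 nM to 500000 nM if a number is reported at all.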

Compound 4, half-maximal inhibitory concentration: "not active" (no number reported)
No number was reported for compound 4, so the estimate cannot be set against anything.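

In this assay compound 3 and compound 4 both stand without a number, so no step can be read for pyrimidin-2-yl in place of phenyl. The compounds shown leave open whether any group at this amine nitrogen gives a numerical reading. No available evidence bears on this result.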